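The source may report more compounds than this note shows. Statements on the series, on what has been measured and on what is new or still open speak of the compounds shown alone.

Measured compounds:
- compound 1, `Cc1nccc2nn(-c3ccccc3)cc12`: > 100000 nM
- compound 2, `CCCCc1cc2nn(-c3ccccc3)cc2cn1`: 13300 nM
- compound 3, `CCCCCc1cc2nn(-c3ccccc3)cc2cn1`: 11800 nM

Within the data shown here, in a functional assay on MCF7 cells (Homo sapiens) for inhibition, read by fluorescence, with a stated time of 72 h (a higher number here means a weaker inhibitor of growth, a lower number a stronger inhibitor of growth), compound 1 gives only a limit, > 100000 nM; no number is known for it, and it is the one value of the three that sits at the limit of > 100000 nM in this assay, at which 1 of the 3 values shown sits. Among the measured compounds shown here, compound 2 gives 13300 nM and compound 3 gives 11800 nM; the one measured step, a 1.1-fold lower number from compound 2 to compound 3 (0.05 log units; within the scatter), lies within the scatter and concerns a saturated chain, not an aromatic ring.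

Compound 4, `Cc1nc(-c2ccccc2)cc2nn(-c3ccccc3)cc12`, differs from compound 1 by phenyl in place of hydrogen on an aromatic carbon. For the measured compounds named here, no measured step bears directly on a phenyl entering at this place, so the direction of the change cannot be read from the data. What can be said is that compound 1, carrying hydrogen there, gives only a limit, while compound 2 and compound 3 give numbers. Compound 4 is therefore expected near 20000 nM, between 5000 nM and 100000 nM. Compound 4 would then be expected to show a step of an at least 5.0-fold lower number from compound 1 to compound 4 (0.69 log units; beyond the scatter).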

Compound 4, concentration for 50% growth inhibition: 11000 nM
Beside the measured number, compound 4's estimate is 1.8-fold (0.26 log units) above it; low and high end bracket the measured number.
By their numbers in this assay, from the lowest: compounds 4, 3 and 2 (each within the scatter of the next). At a limit, above all of these: compound 1.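

In this assay, among these compounds, phenyl in place of hydrogen on this aromatic carbon, next to the ring nitrogen, gives an at least 9.0-fold lower number from compound 1 to compound 4 (0.95 log units; beyond the scatter), the first measured change on an aromatic ring, where the one earlier step, on a saturated chain, lay within the scatter. Compound 4 gives 11000 nM, so a number can be read for this core once phenyl stands at this place. The full size of the step cannot be read because compound 1 stands at a limit: the limit of > 100000 nM in this assay, at which 1 of the 4 values shown sits.

The compounds shown leave open whether this gain belongs to phenyl itself or would also come with another group on this carbon, such as an amine, a carboxylic acid or a methoxy-bearing phenyl. They also leave open how replacing the methyl group with a longer chain would act with phenyl in place.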